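Aryl for Cycloalkyl at the Amide Carbonyl

A few compounds are considered here, and "the series" means these few. Any claim that something is new, unique, unknown or untested is made for them only; others in the source may bear on it.

Compound 1 `CCC(=O)N1CCCn2nc(COc3ccccc3)cc21` gives 48% in a functional assay on HEK293 cells for positive allosteric modulation of metabotropic glutamate receptor 5 (Homo sapiens), read by calcium flux; on this read-out lower numbers stand for smaller maximal responses and higher numbers for larger maximal responses.
Compound 2 `O=C(C1CCC1)N1CCCn2nc(COc3ccccc3)cc21` gives 41% in this assay.
Compound 3 `O=C(C1CCCC1)N1CCCn2nc(COc3ccccc3)cc21` gives 41% in this assay.

Compound 2 stands level with compound 3 at the digits shown, and the two together are the lowest of the three numbers; compound 1 sits higher, but a number 7 percentage points lower from compound 1 to compound 2 (within the scatter) is within the scatter. The step to compound 4 `O=C(c1ccccc1F)N1CCCn2nc(COc3ccccc3)cc21` is 2-fluorophenyl in place of cyclobutyl on a carbonyl carbon. Within the data shown here, no measured step exchanges an alkyl for an aryl group; the steps of a number 7 percentage points lower from compound 1 to compound 3 (within the scatter) and no change at the digits printed from compound 2 to compound 3 (within the scatter) only vary the alkyl group on the carbonyl carbon and all stay within the scatter. Compound 4 is therefore expected near its neighbours, with a number 4 percentage points higher from compound 2 to compound 4 (within the scatter) expected not beyond the scatter, giving an estimate of 45% (range 25% to 70%) in this assay.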

Compound 4, largest response reached (reported as percent of maximum), in percent of the reference or control that the assay uses: 62%
Compound 4: the middle estimate sits 17 percentage points below what was measured; measured number inside the range.
By their numbers in this assay, from the lowest: compounds 2, 3 and 1 (each within the scatter of the next); then compound 4.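

At this place on the carbonyl carbon, ethyl, cyclobutyl and cyclopentyl stay within the scatter of one another in this assay, but 2-fluorophenyl moves the number beyond it (a number 21 percentage points higher from compound 2 to compound 4 (beyond the scatter); a number 21 percentage points higher from compound 3 to compound 4 (beyond the scatter); a number 14 percentage points higher from compound 1 to compound 4 (beyond the scatter)). Compound 4 therefore has the highest number of the four, and the group at this place can change the maximal response. Nothing measured here accounts for the rise.

Open, from the compounds shown here alone, is whether the rise follows the aromatic ring or the fluorine, which a plain phenyl or a pyridine ring at the same place would help to separate.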